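The source may hold more compounds than are shown below. What is called first, only, known or untested is meant among the compounds shown, and "the series" means these compounds.

Measured so far:
compound 1 `CCCCn1nc(Cc2ccc(SC)cc2)c2ccccc2c1=O`: > 100000 nM
compound 2 `O=c1c2ccccc2c(Cc2ccc(Cl)cc2)nn1-c1ccc(Br)cc1`: > 30000 nM

In a functional assay on aorta with Alpha-1D adrenergic receptor (Rattus norvegicus) as the target (a higher number here means that more compound is needed for the effect, a lower number that less compound is needed), compound 1 gives only a limit, > 100000 nM. In this assay compound 2 also gives only a limit, > 30000 nM. Since both values are limits, compound 2 cannot be placed above or below compound 1. Compound 3 `CCCCn1nc(Cc2ccc(Cl)cc2)c2ccccc2c1=O` differs from compound 2 by butyl in place of 4-bromophenyl on an aromatic nitrogen. Compound 1 already carries butyl at that position and gives only a limit, > 100000 nM. The step expected from compound 2 to compound 3 is therefore a step that the limit leaves unreadable from compound 2 to compound 3, none beyond the scatter. Compound 3 is estimated at 100000 nM, range 20000 nM to 300000 nM, most probably again a limit.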

Compound 3, half-maximal effective concentration: > 100000 nM
Compound 3: only a limit was reported; the forecaster's own chance of this, stated with the estimate: 80%; the middle value sits exactly at the limit.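

In this assay, among these compounds, compound 1, compound 2 and compound 3 give only limits, so no step to compound 3 can be read from compound 1 or compound 2. The compounds shown leave open whether either exchange changes the concentration needed for the effect.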